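The source may hold more compounds than are shown below. What is called first, only, known or untested is meant among the compounds shown, and "the series" means these compounds.

Measured so far:
Compound 1, `COc1ccc(CNC(=O)/C=C/c2coc3cc(O)ccc3c2=O)cc1` — in a functional assay on Huh-7 cells (Homo sapiens) for inhibition, read by MTT assay, with a stated time of 48 h (a lower number here means a stronger inhibitor, a higher number a weaker inhibitor), compound 1 gives 8430 nM.
Compound 2, `COc1ccc2c(=O)c(/C=C/C(=O)Nc3ccccc3Cl)coc2c1` — in this assay compound 2 gives 58400 nM.

Of the two numbers shown, compound 2 stands at the highest, which means it is the weaker inhibitor of the pair; compound 1 sits well away from it, beyond the usual scatter. Within the data shown here, the two differ in more than one place, so no single step between them can be named.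

Compound 3, `COc1ccc2c(=O)c(/C=C/C(=O)Nc3ccccc3OC)coc2c1`, has not yet been measured. It differs from compound 2 by methoxy in place of chloro on an aromatic carbon, that is, a methoxy in place of a chloro on an aromatic carbon. Among the measured compounds shown here, with no measured pair showing what this exchange does, the expectation is a step of modest size in this assay, likely within the scatter or only a little beyond it, in either direction. The expected step from compound 2 to compound 3 is a 1.5-fold lower number from compound 2 to compound 3 (0.16 log units; within the scatter). Compound 3 is therefore estimated at 40000 nM, with a range from 10000 nM to 150000 nM.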

Compound 3, half-maximal inhibitory concentration: 32300 nM
Estimate against measurement, compound 3: 1.2-fold (0.09 log units) above; low and high end bracket the measured number.
By their numbers in this assay, from the lowest: compound 1; then compounds 3 and 2 (each within the scatter of the next).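

Among these compounds, this is the first exchange at a single place that can be read: on an aromatic carbon ortho to a large group, methoxy in place of chloro gives a 1.8-fold lower number from compound 2 to compound 3 (0.26 log units; within the scatter) in this assay. At this position, then, the two groups cannot be told apart by this measurement, even though methoxy, unlike chloro, carries a hydrogen-bond acceptor. Nothing at hand explains this result.

The compounds shown hold only these two groups at this position, so whether an amine or a carboxylic acid there would move the number beyond the scatter stays open. Among the compounds shown here, with only one pair carrying this exchange, it also remains unknown whether methoxy and chloro would match as closely elsewhere on the ring.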